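Aryl swap on the ring nitrogen: compound 2 to compound 3

The compounds below may be only part of what the source reports. "The series", "measured", "known", "first", "only" and "open" are said of these compounds alone.

Compound 1 `CC1(C)[C@H]2CC[C@]1(C)N(Cc1cn(-c3cccc(F)c3)nn1)C(=O)C2` and compound 2 `CC1(C)[C@H]2CC[C@]1(C)N(Cc1cn(-c3ccccc3F)nn1)C(=O)C2` share one core and differ only in the fluorophenyl group on the aromatic nitrogen. In a functional assay on OVCAR-3 cells (Homo sapiens) for inhibition, read by MTT assay, with a stated time of 24 h (on this read-out higher numbers stand for weaker inhibition and lower numbers for stronger inhibition), compound 1 gives 430 nM and compound 2 gives 300 nM. The step of a 1.4-fold lower number from compound 1 to compound 2 (0.16 log units; within the scatter) lies within the scatter, so the two numbers cannot be told apart. On the two values shown, compound 2 carries the lower number, with compound 1 nearest to it.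

Compound 3 `CC1(C)[C@H]2CC[C@]1(C)N(Cc1cn(-c3ccc(Cl)cc3)nn1)C(=O)C2` follows from compound 2 by a change at the same place: 4-chlorophenyl in place of 2-fluorophenyl on an aromatic nitrogen. Within the data shown here, the only measured step that bears on this change is a 1.4-fold lower number from compound 1 to compound 2 (0.16 log units; within the scatter), which moved the fluorine around the phenyl and stayed within the scatter. Among the measured compounds shown here, no measured step replaces fluorine with chlorine on this phenyl, so that part of the change has no precedent. On this basis no step beyond the scatter is expected in this assay, and the estimated step is a 1.2-fold higher number from compound 2 to compound 3 (0.07 log units; within the scatter). Compound 3 is estimated at 350 nM, with a range from 150 nM to 900 nM.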

Compound 3, half-maximal inhibitory concentration: 160 nM
For compound 3 the middle estimate is 2.2-fold (0.34 log units) above the measured one; the measured number falls inside the stated range.
By their numbers in this assay, from the lowest: compounds 3, 2 and 1 (each within the scatter of the next, the first and the last beyond it).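

In this assay, among these compounds, 4-chlorophenyl on the aromatic nitrogen gives the first step at this position that lies beyond the scatter, though only a modest one: a 2.7-fold lower number from compound 1 to compound 3 (0.43 log units; beyond the scatter) with 3-fluorophenyl as the group replaced. Against 2-fluorophenyl the same change stays within the scatter, at a 1.9-fold lower number from compound 2 to compound 3 (0.27 log units; within the scatter), so compound 2 and compound 3 cannot be told apart, and the only separation among the three aryl groups is the gap between compound 1 and compound 3. The position therefore tolerates all three halogen-bearing phenyl groups with little change in the numbers, and nothing available bears on why compound 3 separates from compound 1 alone.

Halogen identity and halogen place on the phenyl change together in both new steps, so these compounds cannot assign the gap to either one. Also open, as far as these compounds go, is how the number responds to groups of a different kind on this phenyl, such as an amine or a carboxylic acid, or to a longer chain between the aromatic nitrogen and the phenyl.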